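A few compounds are considered here, and "the series" means these few. Any claim that something is new, unique, unknown or untested is made for them only; others in the source may bear on it.

Compound 1 `COc1ccccc1NS(=O)(=O)c1ccc2nc(-c3ccccc3)c(-c3ccccc3)nc2c1`: 100%
Compound 2 `O=S(=O)(Nc1cccc2ccccc12)c1ccc2nc(-c3ccccc3)c(-c3ccccc3)nc2c1`: 100%
Compound 3 `O=C(NS(=O)(=O)c1ccc2nc(-c3ccccc3)c(-c3ccccc3)nc2c1)c1ccccc1`: 100%

All three were tested in an ADME assay on the whole organism for pharmacokinetics, with Homo sapiens as the target; a lower number here means that a smaller share of the oral dose reaches the circulation, a higher number that a larger share of the oral dose reaches the circulation. Compound 1 stands level with both others: no change at the digits printed from compound 1 to compound 2 (within the scatter) and no change at the digits printed from compound 1 to compound 3 (within the scatter), and likewise no change at the digits printed from compound 2 to compound 3 (within the scatter). Compound 4 `O=S(=O)(Nc1ccc2ccccc2c1)c1ccc2nc(-c3ccccc3)c(-c3ccccc3)nc2c1` differs from compound 1 in one place: naphthalen-2-yl in place of 2-methoxyphenyl on a sulfonamide nitrogen. Among the measured compounds shown here, the step that bears most on this change is the one to compound 2, no change at the digits printed from compound 1 to compound 2 (within the scatter), where a naphthalen-1-yl replaced the same 2-methoxyphenyl on the sulfonamide nitrogen without any shift beyond the scatter. The step to compound 3, no change at the digits printed from compound 1 to compound 3 (within the scatter), points the same way. Compound 4 is therefore expected to show no change beyond the scatter, a number 5 percentage points lower from compound 1 to compound 4 (within the scatter). The estimate for compound 4 is 95%, in the range 80% to 100%.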

Compound 4, oral bioavailability: 100%
The estimate for compound 4 lay 5 percentage points below the measured number, and the stated range covers the measured number.
By their numbers in this assay, from the lowest: compounds 1, 2, 3 and 4 (each within the scatter of the next).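

In this assay this position on the sulfonamide nitrogen now also tolerates a naphthalen-2-yl group, with no change at the digits printed from compound 1 to compound 4 (within the scatter) and no change at the digits printed from compound 3 to compound 4 (within the scatter). Moving the attachment point of the naphthalene adds a new kind of change, and it too leaves the read-out flat, with no change at the digits printed from compound 2 to compound 4 (within the scatter). No available evidence explains this flat result.

All the groups shown at this position are large and carry an aromatic ring, so a small methyl, an amine-bearing chain or a carboxylic acid there remains open. Changes to the shared core remain open as well.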